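A Phenylsulfonyl Group on the Ring Nitrogen of Compound 2

The compounds below may be only part of what the source reports. "The series", "measured", "known", "first", "only" and "open" are said of these compounds alone.

Among the measured compounds shown here, only two compounds have results so far in a functional assay on MCF7 cells (Homo sapiens) for antiproliferative activity, read by sulforhodamine B assay, with a stated time of 72 h; on this read-out higher numbers stand for weaker inhibition and lower numbers for stronger inhibition. Compound 1 `CC(=O)n1cc(/C=C2\CCC=CC2=O)c2ccccc21` gives 5440 nM, a true measured number. Compound 2 `COc1cc(/C=C2\CNC=CC2=O)cc(OC)c1OC` gives > 25000 nM, which is a limit of the assay and not a number. No exact value is therefore known for compound 2.

Compound 3 `COc1cc(/C=C2\CN(S(=O)(=O)c3ccccc3)C=CC2=O)cc(OC)c1OC` is compound 2 with a single change: phenylsulfonyl in place of hydrogen on an amine nitrogen in a ring. Put simply, phenylsulfonyl takes the place of hydrogen on an amine nitrogen in a ring. For the measured compounds named here, no measured pair yet shows what this kind of change does in this assay, so any forecast carries wide uncertainty.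

Going by the values given here, the only firm number to lean on comes from compound 1, whose 5440 nM shows that a related compound can give a measurable result here. On that slender basis, a step toward stronger inhibition, larger than the usual scatter, is expected. The estimated change is an at least 6.2-fold lower number from compound 2 to compound 3 (0.79 log units; beyond the scatter). Compound 3 is expected to give about 4000 nM, with an estimated range of 600 nM to 22000 nM.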

Compound 3, half-maximal inhibitory concentration: > 25000 nM
Compound 3: a limit, no number (the forecaster's own chance of this, stated with the estimate: 15%); middle value at least 6.2-fold (0.79 log units) away from the limit.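

In this assay compound 3 gives > 25000 nM, which is a limit of the assay and not a number. Among the compounds shown here, compound 2 also stands at a limit, so no step between compound 2 and compound 3 can be read, and the two share this value: the limit of > 25000 nM in this assay, at which 2 of the 3 values shown sit.

On these data alone, whether phenylsulfonyl in place of hydrogen changes inhibition at all, and in which direction, stays open.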